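This account rests on a few compounds, and the source may have more. Where it says the series, first, only, none or still open, it means among the compounds named here.

In a functional assay on OCI-Ly3 cells (Homo sapiens) for inhibition, read by CellTiter-Glo, with stated times of 48 h and 96 h (a higher number here means a weaker inhibitor of growth, a lower number a stronger inhibitor of growth), three compounds have been measured:
- compound 1 `CC(C)[C@H](NC(=O)c1ccc(C#N)cc1)C(=O)N1CCC[C@H]1C(=O)N[C@@H](CCCNC(=N)N)C(=O)CF`: 6660 nM
- compound 2 `CC(C)[C@H](NC(=O)c1ccc(C(F)(F)F)cc1)C(=O)N1CCC[C@H]1C(=O)N[C@@H](CCCNC(=N)N)C(=O)CF`: 120 nM
- compound 3 `CC(C)c1ccc(C(=O)N[C@H](C(=O)N2CCC[C@H]2C(=O)N[C@@H](CCCNC(=N)N)C(=O)CF)C(C)C)cc1`: 270 nM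

Compound 3, at 270 nM, has the second highest of the three numbers. Compound 4 `CC(C)[C@H](NC(=O)Nc1ccccc1)C(=O)N1CCC[C@H]1C(=O)N[C@@H](CCCNC(=N)N)C(=O)CF` carries anilino in place of 4-isopropylphenyl on a carbonyl carbon.

Going by the values given here, no measured step makes this exact change. The closest evidence comes from swaps of a group on an aromatic carbon: there is a large step, a 25-fold lower number from compound 1 to compound 3 (1.39 log units; beyond the scatter), and a modest one, a 2.3-fold higher number from compound 2 to compound 3 (0.35 log units; beyond the scatter). Together they suggest that changes in this region can shift the number widely, so the range must stay broad.

A moderate rise is expected: a 3.0-fold higher number from compound 3 to compound 4 (0.47 log units; beyond the scatter). The estimate for compound 4 is 800 nM, with an expected range of 200 nM to 3500 nM.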

Compound 4, concentration for 50% growth inhibition: 1520 nM
Compound 4: the middle estimate sits 1.9-fold (0.28 log units) below what was measured, and the stated range covers the measured number.
By their numbers in this assay, from the lowest: compound 2; then compound 3; then compound 4; then compound 1.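

Putting anilino on the carbonyl carbon gives, in this assay, a 5.6-fold higher number from compound 3 to compound 4 (0.75 log units; beyond the scatter) and a 13-fold higher number from compound 2 to compound 4 (1.10 log units; beyond the scatter), but also a 4.4-fold lower number from compound 1 to compound 4 (0.64 log units; beyond the scatter). So compound 4 falls inside the spread set by the three substituted phenyl groups, above two of them and below the 4-cyanophenyl one. Nothing available explains these differences.

This change adds a nitrogen and removes the ring substituent at once, so the two effects cannot be told apart. A plain phenyl on the same carbonyl carbon, or a 4-isopropylanilino group, would separate them.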